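Methoxy Replacing Chloro on the Aryl Ring

A few compounds are considered here, and "the series" means these few. Any claim that something is new, unique, unknown or untested is made for them only; others in the source may bear on it.

Compound 3 `O=C(N/N=C/c1ccccc1O)c1cc(-c2ccc(Cl)cc2)nn1Cc1ccccc1` in a functional assay on A549 cells (Homo sapiens) for cytotoxicity, read by MTT assay, with a stated time of 48 h (on this read-out higher numbers stand for weaker inhibition and lower numbers for stronger inhibition), gives 4690 nM. Compound 2 `O=C(N/N=C/c1ccccc1O)c1cc(-c2ccccc2)nn1Cc1ccccc1` gives 11000 nM and compound 1 `COc1ccc(-c2cc(C(=O)N/N=C/c3ccccc3O)n(Cc3ccc(Cl)nc3)n2)cc1` gives 8120 nM; compound 3 sits beyond the scatter from compound 2, while its gap to compound 1 falls within it. Among the compounds with values here, the only measured single change is a 2.3-fold lower number from compound 2 to compound 3 (0.37 log units; beyond the scatter). Compound 4 `COc1ccc(-c2cc(C(=O)N/N=C/c3ccccc3O)n(Cc3ccccc3)n2)cc1` differs from compound 3 by methoxy in place of chloro on an aromatic carbon. Within the data shown here, no measured step shows methoxy against chloro at this carbon; compound 1 carries the methoxyphenyl too, but differs elsewhere as well. Compound 4 is therefore expected to stay near compound 3, with the change a 1.5-fold higher number from compound 3 to compound 4 (0.17 log units; within the scatter) expected to lie within the scatter, for an estimated 7000 nM in the range 3500 nM to 14000 nM.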

Compound 4, half-maximal inhibitory concentration: 7420 nM
The estimate for compound 4 lay 1.1-fold (0.03 log units) below the measured number; the measured number falls inside the stated range.
By their numbers in this assay, from the lowest: compounds 3, 4, 1 and 2 (each within the scatter of the next, the first and the last beyond it).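

In this assay methoxy in place of chloro on this aromatic carbon gives a 1.6-fold higher number from compound 3 to compound 4 (0.20 log units; within the scatter) and so does not separate the two groups. Methoxy in place of hydrogen gives a 1.5-fold lower number from compound 2 to compound 4 (0.17 log units; within the scatter) while chloro in place of hydrogen gave a 2.3-fold lower number from compound 2 to compound 3 (0.37 log units; beyond the scatter) at the same carbon. Phenyl in place of 6-chloropyridin-3-yl gives a 1.1-fold lower number from compound 1 to compound 4 (0.04 log units; within the scatter) with the methoxyphenyl held constant. On these data alone, whether an amine or a carboxylic acid on this carbon would shift the number further remains open. Nothing available explains any of these steps.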